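Methylthiazolyl for bromophenyl on the carbonyl carbon

The source may report more compounds than this note shows. Statements on the series, on what has been measured and on what is new or still open speak of the compounds shown alone.

Two compounds of the series carry a result in an assay on isolated protein for inhibition of Rho-associated protein kinase 1 (Homo sapiens), read by scintillation counting, radiometric assay and 33P incorporation, with a stated time of 40 min, in the presence of a further agent that is not named here; on this read-out lower numbers stand for stronger inhibition and higher numbers for weaker inhibition. Compound 1 `CN(C)c1ccc(C(=O)Nc2cccc(NC(=O)COc3ccc4c(c3)OCCO4)c2)cc1` gives > 10000 nM there, which is a limit of the assay rather than a number. That limit is the limit of > 10000 nM in this assay, at which 1 of the 2 values shown sits. Compound 2 `O=C(COc1ccc2c(=O)ccoc2c1)Nc1cccc(NC(=O)c2ccc(Br)cc2)c1` gives 303 nM in this assay; it is the only number shown in the set, so its standing cannot be placed against another measured compound. Compound 3 `Cc1nc(C(=O)Nc2cccc(NC(=O)COc3ccc4c(=O)ccoc4c3)c2)cs1` has not yet been measured in this assay. Its difference from compound 2 is 2-methyl-1,3-thiazol-4-yl in place of 4-bromophenyl on a carbonyl carbon. Among the compounds with values here, no step between measured compounds is available to calibrate this change. Without such a reference the expectation for this assay is a step of modest size tending toward weaker inhibition, though a result within the scatter around compound 2 would not surprise. Compound 3 is therefore estimated at 800 nM, with a range from 200 nM to 3500 nM. The step this estimate implies is expected to be a 2.6-fold higher number from compound 2 to compound 3 (0.42 log units; beyond the scatter).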

Compound 3, half-maximal inhibitory concentration: 473 nM
Beside the measured number, compound 3's estimate is 1.7-fold (0.23 log units) above it; the range from low to high includes it.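

In this assay, within the data shown here, the step of a 1.6-fold higher number from compound 2 to compound 3 (0.19 log units; within the scatter) is the first that can be read. On a carbonyl carbon whose other neighbour is an amide-type nitrogen, a five-membered aromatic ring with 2 hetero atoms and a methyl group therefore takes the place of a bromine-bearing six-membered aromatic ring with no separable change in this read-out. Nothing on hand offers an explanation for this result.

Whether the ring, its methyl group or the bromine matters at this position stays open: the compounds shown include no unsubstituted phenyl, no pyridine ring and no phenyl carrying an amine or a carboxylic acid. Compound 1 differs from compound 2 and compound 3 in more than one place, so it gives no reading on this change. Compound 1 gives > 10000 nM, which is a limit of the assay.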